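Working notes: isobutyl to sec-butyl on the amine nitrogen

The compounds below may be only part of what the source reports. "The series", "measured", "known", "first", "only" and "open" are said of these compounds alone.

Measured in a functional assay on HT-29 cells (Homo sapiens) for inhibition, read by sulforhodamine B assay, with a stated time of 72 h; on this read-out lower numbers stand for stronger inhibition and higher numbers for weaker inhibition:
- compound 1 `COc1cc(/C=C/C(=O)/C=C(/C=C/c2ccc(OC(C)=O)c(OC)c2)NC2CCCCC2)ccc1OC(C)=O`: > 25000 nM, a limit
- compound 2 `COc1cc(/C=C/C(=O)/C=C(/C=C/c2ccc(OC(C)=O)c(OC)c2)NCC(C)C)ccc1OC(C)=O`: > 25000 nM, a limit

Compound 2 gives no number, only the limit > 25000 nM. Compound 3 `CCC(C)NC(=C\C(=O)/C=C/c1ccc(OC(C)=O)c(OC)c1)/C=C/c1ccc(OC(C)=O)c(OC)c1` has sec-butyl in place of isobutyl on an amine nitrogen. Among the measured compounds shown here, the one measured step bearing on this, a step that the two limits leave unreadable from compound 1 to compound 2, has no readable size. For the measured compounds named here, the series so far rests on (the limit of > 25000 nM in this assay, at which 2 of the 2 values shown sit). In this assay, the expected step that the limit leaves unreadable from compound 2 to compound 3 therefore stays within the scatter. The estimate for compound 3 is 30000 nM, with an expected range of 15000 nM to 60000 nM.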

Compound 3, half-maximal inhibitory concentration: > 25000 nM
Compound 3: only a limit was reported; the forecaster's own chance of this, stated with the estimate: 80%; the middle value is on the limit's open side.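

In this assay compound 3 gives > 25000 nM, a limit. Among the compounds shown here, no step among compound 1, compound 2 and compound 3 can therefore be read. The compounds shown leave open how cyclohexyl, isobutyl and sec-butyl on the amine nitrogen compare in this read-out.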